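Switching the aryl group on the saturated ring carbon of compound 3

The source may hold more compounds than are shown below. What is called first, only, known or untested is meant among the compounds shown, and "the series" means these compounds.

Of the compounds shown here, three sharing one core have been measured in a functional assay on Ehrlich cells (Mus musculus) for antiproliferative activity, read by trypan blue exclusion, with a stated time of 2 h, tested at 25 ug/mL; on this read-out lower numbers stand for a weaker effect and higher numbers for a stronger effect at the one concentration tested. Compound 1 `N#CC1=C(N)N(c2ccc(S(N)(=O)=O)cc2)C2=C(C(=O)CCC2)C1c1ccccc1` gives 30%. Compound 2 `N#CC1=C(N)N(c2ccc(S(N)(=O)=O)cc2)C2=C(C(=O)CCC2)C1/C=C/c1ccccc1` gives 10%. Compound 3 `N#CC1=C(N)N(c2ccc(S(N)(=O)=O)cc2)C2=C(C(=O)CCC2)C1c1cccc([N+](=O)[O-])c1` gives 50%, the highest of the three numbers, with compound 1 nearest and compound 2 furthest. The steps between them were modest to large: a number 20 percentage points lower from compound 1 to compound 2 (beyond the scatter), a number 20 percentage points higher from compound 1 to compound 3 (beyond the scatter) and a number 40 percentage points higher from compound 2 to compound 3 (beyond the scatter).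

Compound 4 `COc1ccc2ccccc2c1C1C(C#N)=C(N)N(c2ccc(S(N)(=O)=O)cc2)C2=C1C(=O)CCC2` has not yet been measured. It differs from compound 3 in one place: 2-methoxynaphthalen-1-yl in place of 3-nitrophenyl on a saturated ring carbon. For the measured compounds named here, two measured steps bear on this change. The step from compound 1 to compound 3 showed that adding a nitro group raised the read-out beyond the scatter, so its removal is expected to pull the number back toward that of compound 1. The step from compound 1 to compound 2 showed that a different group at this saturated ring carbon can lower the read-out further. Going by the values given here, no measured compound carries a naphthalene ring, so the effect of the added ring and its methoxy group is unknown. A drop of modest size, a number 20 percentage points lower from compound 3 to compound 4 (beyond the scatter), is therefore expected, with wide uncertainty. Compound 4 is estimated to give 30% in this assay, within 10% to 55%.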

Compound 4, a percentage reported as activity, at one concentration (the size of the read-out at that concentration, not a potency): 62%
For compound 4 the middle estimate is 32 percentage points below the measured one; the whole stated range lies below it.
By their numbers in this assay, from the lowest: compound 2; then compound 1; then compound 3; then compound 4.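

In this assay the 2-methoxynaphthalen-1-yl group gives the highest number of the four compounds, above 3-nitrophenyl (a number 12 percentage points higher from compound 3 to compound 4 (beyond the scatter)), phenyl (a number 32 percentage points higher from compound 1 to compound 4 (beyond the scatter)) and 2-phenylethenyl (a number 52 percentage points higher from compound 2 to compound 4 (beyond the scatter)). At this saturated ring carbon, then, a nitro group is not needed for the highest read-out in this set, and a group with two aromatic rings and more heavy atoms than 3-nitrophenyl is accepted with a gain rather than a loss. No measurement here accounts for that gain, and this single change swaps the ring system and its substituent together, so the result cannot be credited to either one alone.

The compounds shown leave open whether the gain follows the second aromatic ring or the methoxy group, a question that a plain naphthalen-1-yl and a 2-methoxyphenyl group at the same carbon could separate. They also leave open how an amine or a carboxylic acid on the aromatic ring would behave, and, with only one concentration tested, how these compounds compare in potency.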